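Demethylation step in an indole chalcone series

The source may hold more compounds than are shown below. What is called first, only, known or untested is meant among the compounds shown, and "the series" means these compounds.

Compound 1 `COc1ccc2[nH]cc(/C=C/C(=O)c3ccncc3)c2c1` gives 2% in a functional assay on U-251 cells (Homo sapiens) for inhibition, read by colony formation, with stated times of 48 h and 2 weeks, tested at 10 uM; on this read-out higher numbers stand for more inhibition at the one concentration tested (going by the name of the read-out) and lower numbers for less inhibition; compound 2 `O=C(/C=C/c1c[nH]c2ccc(O)cc12)c1ccncc1` gives 72%; compound 3 `COC(=O)c1ccc(COc2ccc3[nH]c(C)c(/C=C/C(=O)c4ccncc4)c3c2)cc1` gives 76%.

For the measured compounds named here, the one counted step, (hydrogen in place of methyl on an oxygen on an aromatic ring), runs a number 70 percentage points higher from compound 1 to compound 2 (beyond the scatter). Compound 3 carries a different core; the difference between the core of compound 3 and the core of compound 1 is not broken down here. Compound 4 `Cc1[nH]c2ccc(OCc3ccc(C(=O)O)cc3)cc2c1/C=C/C(=O)c1ccncc1` is unmeasured and differs from compound 3 by hydrogen in place of methyl on an oxygen next to a carbonyl group. This is the same kind of change as from compound 1 to compound 2, but the place differs: there the oxygen sits on an aromatic ring with an aromatic carbon as other neighbour, here next to a carbonyl group with the carbonyl carbon as other neighbour. A step of no change at the digits printed from compound 3 to compound 4 (within the scatter) is expected, because compound 3 already gives 76% and leaves little room above it. Compound 4 is expected to give 76%, between 55% and 92%.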

Compound 4, a percentage reported as inhibition, at one concentration (the size of the read-out at that concentration, not a potency): 71%
Estimate against measurement, compound 4: 5 percentage points above, within the range that was stated.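

In this assay, replacing methyl with hydrogen on an oxygen does not give one transferable result, as the two steps are clearly apart: the same change on two cores in this assay, a number 70 percentage points higher (beyond the scatter) from compound 1 to compound 2 and a number 5 percentage points lower (within the scatter) from compound 3 to compound 4, 75 percentage points apart, beyond the scatter of two such steps
The methoxycarbonyl to carboxy change gives a number 5 percentage points lower from compound 3 to compound 4 (within the scatter), so the large step seen with methoxy to hydroxy does not recur at this second site. This pair does not separate the effect of the core from that of the oxygen's place, on an aromatic ring in one step and next to a carbonyl group in the other.

Still open, going by these compounds, is the methoxy to hydroxy change on the core of compound 3, which would hold the place constant. Also open, on these data alone, is how an amide or an amine would read in place of the carboxy group of compound 4.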